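The source may report more compounds than this note shows. Statements on the series, on what has been measured and on what is new or still open speak of the compounds shown alone.

Measured so far:
- compound 1, `CCCCCCCCCCCCCCCCc1nc(N2CCC2)nc(OC2CCC2)c1O`: 114%
- compound 2, `CCCCCCCCCCCCCCCCc1nc(OC2CCC2)nc(N2CCC2)c1O`: 110%
- compound 3, `CCCCCCCCCCCCCCc1nc(N2CCC2)nc(N2CCC2)c1O`: 46%

In a functional assay on cells (Lymphocyte, Homo sapiens), read by a luciferase reporter and ATP content, with a stated time of 48 h, tested at 5 uM (on this read-out lower numbers stand for a stronger effect and higher numbers for a weaker effect at the one concentration tested), compound 1 gives 114% and compound 2 gives 110%; these two numbers lie within the scatter of each other, so nothing separates them. Compound 3 gives 46%, the lowest of the three numbers and beyond the scatter from both of the others, so among these three it has the strongest effect. Compound 3 is also the only one of the three that carries the shorter saturated chain, while each of compounds 1 and 2 carries a ring-bearing oxygen substituent in place of one of the two nitrogen-linked rings, so the chain and the substituents change together and cannot be told apart here.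

Compound 4, `CCCCCCCCCCCCCCCCc1nc(N2CCC2)nc(N2CCC2)c1O`, differs from compound 3 in one place: ethyl in place of hydrogen on a saturated chain carbon, ten or more bonds along the chain from an aromatic carbon. Within the data shown here, no pair of measured compounds shows this change on its own, so the step from compound 3 to compound 4 in this assay is unknown. Because compound 3 gives 46% and the change sits far out along the chain, a step of modest size is expected, likely within the scatter, in either direction. The expected step of a number 2 percentage points higher from compound 3 to compound 4 (within the scatter) is small. Compound 4 is estimated at 48%, within 25% to 75%.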

Compound 4, a percentage reported as activity, at one concentration (the size of the read-out at that concentration, not a potency): 61%
Compound 4: middle estimate off by 13 percentage points, on the low side; the range from low to high includes it.
By their numbers in this assay, from the lowest: compound 3; then compound 4; then compounds 2 and 1 (each within the scatter of the next).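

In this assay, the change at the far end of the chain is not silent: ethyl in place of hydrogen on a saturated chain carbon, ten or more bonds along the chain from an aromatic carbon, gives a number 15 percentage points higher from compound 3 to compound 4 (beyond the scatter), a modest step towards a weaker effect at the one concentration tested. Among these compounds, with the chain held the same, azetidin-1-yl in place of cyclobutyloxy on an aromatic carbon gives a number 49 percentage points lower from compound 2 to compound 4 (beyond the scatter) and a number 53 percentage points lower from compound 1 to compound 4 (beyond the scatter), both large steps towards a stronger effect, so the two changes that ran together in the earlier compounds can now be read apart, and the swap of the ring group is the large one whichever of the two aromatic carbons carries the cyclobutyloxy group. Nothing available explains why either change moves the number.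

The compounds shown leave open whether the effect keeps weakening along a longer chain or grows stronger along a chain shorter than the one in compound 3. They also leave open whether a pyrrolidine ring or a dimethylamino group could stand in for azetidin-1-yl on the shared core.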